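The source may hold more compounds than are shown below. What is called first, only, known or untested is meant among the compounds shown, and "the series" means these compounds.

Measured so far in a functional assay on HCT-15 cells (Homo sapiens) for cytotoxicity, read by sulforhodamine B assay, with a stated time of 48 h, tested at 1 uM; on this read-out lower numbers stand for a stronger effect and higher numbers for a weaker effect at the one concentration tested:
compound 1 `COc1ccc(-c2cc(/C=C/C(=O)c3ccc(OC)c(OC)c3)[nH]n2)cc1`: 65%
compound 2 `COc1cc(-c2cc(/C=C/C(=O)c3ccc(Cl)c(Cl)c3)[nH]n2)cc(OC)c1OC`: 86%
compound 3 `COc1ccc(-c2cc(/C=C/C(=O)c3ccc(N)cc3)[nH]n2)cc1`: 50%

Compound 2 gives the highest of the three numbers, the weakest effect in the set; compound 1 sits below it and compound 3 furthest below, both beyond the scatter. Among the measured compounds shown here, no single-point steps between the measured compounds are at hand, so only the values themselves are known.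

As far as these compounds go, compound 4 `COc1ccc(C(=O)/C=C/c2cc(-c3cc(OC)c(OC)c(OC)c3)n[nH]2)cc1OC` is untested. It differs from compound 2 by 3,4-dimethoxyphenyl in place of 3,4-dichlorophenyl on a carbonyl carbon. Compound 1 also carries a 3,4-dimethoxyphenyl on the carbonyl carbon and gives 65%, a lower number than compound 2, though the two differ elsewhere as well. A downward step a number 14 percentage points lower from compound 2 to compound 4 (beyond the scatter) is therefore expected, of moderate size. For compound 4 the estimate in this assay is 72%, within 52% to 90%.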

Compound 4, a percentage reported as activity, at one concentration (the size of the read-out at that concentration, not a potency): 65%
Compound 4: the middle estimate sits 7 percentage points above what was measured; the range from low to high includes it.
By their numbers in this assay, from the lowest: compound 3; then compounds 1 and 4 (each within the scatter of the next); then compound 2.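

In this assay, among the compounds shown here, 3,4-dimethoxyphenyl in place of 3,4-dichlorophenyl on the carbonyl carbon gives a number 21 percentage points lower from compound 2 to compound 4 (beyond the scatter) and is the first single-place change. With the rest of the structure held fixed, this position is thus shown to affect the read-out, and the ring substituents alone separate the two compounds. No measured property accounts for the step. Still open, as far as these compounds go, is how a carboxylic acid or a longer chain on the aromatic ring at this position would read, and whether the step holds on the core of compound 1.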